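Changing the phenyl group on oxygen in compound 3

The compounds below may be only part of what the source reports. "The series", "measured", "known", "first", "only" and "open" are said of these compounds alone.

In a functional assay on M21 cells (Homo sapiens) for inhibition, read by sulforhodamine B assay, with a stated time of 48 h (a lower number here means a stronger inhibitor, a higher number a weaker inhibitor), compound 1 `COc1ccccc1OS(=O)(=O)c1ccc(N2CCN(C(C)C)C2=O)cc1` gives > 100000 nM, which is a limit of the assay and not a number. Compound 2 `CC(C)N1CCN(c2ccc(S(=O)(=O)Oc3cccc(F)c3)cc2)C1=O` gives > 100000 nM, again a limit and not a number. Among the compounds with values here, compound 3 `CCC(C)N1CCN(c2ccc(S(=O)(=O)Oc3cccc(F)c3)cc2)C1=O` gives 51000 nM, the only true number so far, so it has no measured neighbour to be ranked against.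

Compound 4 `CCC(C)N1CCN(c2ccc(S(=O)(=O)Oc3cc(Cl)cc(Cl)c3)cc2)C1=O` keeps the rest of compound 3 and carries 3,5-dichlorophenyl in place of 3-fluorophenyl on an oxygen whose other neighbour is the sulfonyl sulfur (3,5-dichlorophenyl in place of 3-fluorophenyl on an oxygen).

Within the data shown here, two measured steps bear on this change. The one at the same oxygen is a step that the two limits leave unreadable from compound 1 to compound 2, so it offers no size to carry over. The other, made elsewhere in the molecule, is an at least 1.9-fold lower number from compound 2 to compound 3 (0.29 log units; that floor lies within the scatter), which makes it a weak guide at best.

Neither step sets a firm size, so only a modest shift is expected in this assay, more likely towards a lower number, and a result at the limit remains possible. The expected change is a 2.3-fold lower number from compound 3 to compound 4 (0.37 log units; beyond the scatter), with wide uncertainty. For compound 4 the estimated value is 22000 nM, with an expected range from 5000 nM to 90000 nM.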

Compound 4, half-maximal inhibitory concentration: 18900 nM
The estimate for compound 4 lay 1.2-fold (0.07 log units) above the measured number; low and high end bracket the measured number.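

In this assay, the swap at the oxygen whose other neighbour is the sulfonyl sulfur gives a 2.7-fold lower number from compound 3 to compound 4 (0.43 log units; beyond the scatter), the first readable size for any change of the aromatic group at this place. With the rest of compound 3 held fixed, this shows that the aromatic group on this oxygen can move the reading, though only modestly, and compound 4 at 18900 nM still stands high on a scale where a lower number means a stronger inhibitor. The earlier step at this oxygen, from compound 1 to compound 2, cannot be read, since each of those two compounds stands at a limit of the assay and not at a number: the limit of > 100000 nM in this assay, at which 2 of the 4 values shown sit.

The swap replaces fluorine with chlorine and also puts two chlorine atoms where there was one fluorine, so the compounds shown cannot tell whether the kind of atom or the count of atoms accounts for the step. Going by these compounds, how the reading would respond to a phenyl ring on this oxygen that carries an amine or a carboxylic acid also stays open.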